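This account rests on a few compounds, and the source may have more. Where it says the series, first, only, none or still open, it means among the compounds named here.

In a functional assay on MCF7 cells (Homo sapiens) for antiproliferative activity, read by sulforhodamine B assay, with a stated time of 48 h (on this read-out higher numbers stand for weaker inhibition and lower numbers for stronger inhibition), the measured compounds read:

Compound 1 `Cc1cccc(NS(=O)(=O)c2ccc(N3CCNC3=O)cc2)c1`: 190 nM
Compound 2 `O=C1NCCN1c1ccc(S(=O)(=O)Nc2ccc(I)cc2)cc1`: 600 nM
Compound 3 `Cc1ccc(C)c(NS(=O)(=O)c2ccc(N3CCNC3=O)cc2)c1`: 48 nM

Compound 3 has the lowest number of the three, which makes it the strongest inhibitor so far. The next compound, compound 4 `O=C1NCCN1c1ccc(S(=O)(=O)Nc2cccc(Cl)c2)cc1`, has not been measured. It carries 3-chlorophenyl in place of 2,5-dimethylphenyl on a sulfonamide nitrogen.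

The measured steps all change this same aryl group on the sulfonamide nitrogen. The large one is a 13-fold lower number from compound 2 to compound 3 (1.10 log units; beyond the scatter), and the two modest ones are a 3.2-fold higher number from compound 1 to compound 2 (0.50 log units; beyond the scatter) and a 4.0-fold lower number from compound 1 to compound 3 (0.60 log units; beyond the scatter). The last of these shows that one added methyl separates compound 1 from compound 3. Leaving 2,5-dimethylphenyl has so far meant a higher number, and the closest guide is compound 1 at 190 nM. A modest rise in this assay is therefore expected, with an estimated 4.2-fold higher number from compound 3 to compound 4 (0.62 log units; beyond the scatter). For compound 4 the estimated value is 200 nM, with an expected range from 70 nM to 550 nM.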

Compound 4, half-maximal inhibitory concentration: 79 nM
Compound 4: the middle estimate sits 2.5-fold (0.40 log units) above what was measured; measured number inside the range.
By their numbers in this assay, from the lowest: compounds 3 and 4 (each within the scatter of the next); then compound 1; then compound 2.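

In this assay, the sulfonamide nitrogen tolerates a change from 2,5-dimethylphenyl to 3-chlorophenyl with no clear change in the number (a 1.6-fold higher number from compound 3 to compound 4 (0.22 log units; within the scatter)). Chloro in place of methyl on the aromatic carbon does count when the two single-substituent rings are compared (a 2.4-fold lower number from compound 1 to compound 4 (0.38 log units; beyond the scatter)), so the identity of one group on this ring can shift the reading beyond the scatter. The move from 4-iodophenyl to 3-chlorophenyl gives a larger drop (a 7.6-fold lower number from compound 2 to compound 4 (0.88 log units; beyond the scatter)), and nothing available explains any of these differences.

That last step changes both the halogen and its numbered ring position, so the two effects cannot be separated. As far as these compounds go, how this ring would read with a methoxy group, an amine or a carboxylic acid in place of chloro remains open.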